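Urea in place of guanidine on the shared core

The compounds below may be only part of what the source reports. "The series", "measured", "known", "first", "only" and "open" are said of these compounds alone.

Compound 2 `C/N=C(/NC)Nc1nc(-c2ccc(OC)cc2)c(-c2ccc(OC)cc2)s1` stands at the highest of the two numbers in a functional assay with Oryctolagus cuniculus as the target (a lower number here means a stronger inhibitor, a higher number a weaker inhibitor), giving 970 nM. For the measured compounds named here, compound 3 `COc1ccc(-c2nc(CNC(=O)C3=NNC(=O)CC3)sc2-c2ccc(OC)cc2)cc1` gives 55 nM in this assay, a gap beyond the scatter; no single step is drawn between these two. Compound 1 `COc1ccc(-c2nc(/N=C(\N)NC(C)C)sc2-c2ccc(OC)cc2)cc1` reports only a limit in this assay, > 100 nM. Compound 4 `COc1ccc(-c2nc(CNC(=O)NC(C)C)sc2-c2ccc(OC)cc2)cc1` is not yet measured; against compound 2 the change is a group of 8 heavy atoms (5 carbon, 2 nitrogen, 1 oxygen; no ring) in place of a group of 6 heavy atoms (3 carbon, 3 nitrogen; no ring), on an aromatic carbon. Going by the values given here, the only measured step that touches compound 2, a step that the limit leaves unreadable from compound 1 to compound 2, has no readable size because the limit of > 100 nM in this assay, at which 1 of the 3 values shown sits, caps what is known of compound 1, so it gives no guide to direction. The remaining guide is compound 3, which with 55 nM sits far under compound 2 while also carrying a carbonyl-bearing chain on an aromatic carbon of the shared core. On that ground compound 4 is expected to improve on compound 2, though not necessarily to the level of compound 3. The expected step is a 4.9-fold lower number from compound 2 to compound 4 (0.69 log units; beyond the scatter), downward and beyond the scatter. Compound 4 is therefore estimated at 200 nM, with a range from 40 nM to 1000 nM.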

Compound 4, half-maximal inhibitory concentration: 42 nM
Compound 4: middle estimate off by 4.8-fold (0.68 log units), on the high side; low and high end bracket the measured number.
By their numbers in this assay, from the lowest: compounds 4 and 3 (each within the scatter of the next); then compound 2.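

In this assay, ((isopropylcarbamoyl)amino)methyl on this aromatic carbon, in place of the group of compound 2, gives a 23-fold lower number from compound 2 to compound 4 (1.36 log units; beyond the scatter), although both groups count the same hydrogen-bond donors and acceptors and neither carries a net charge. Compound 1 stands at a limit, and the change from it can be read only against that limit as an at least 2.3-fold lower number from compound 1 to compound 4 (0.37 log units; beyond the scatter): the limit of > 100 nM in this assay, at which 1 of the 4 values shown sits. On the carbonyl carbon, the open isopropylamino group in place of the ring-bearing group of compound 3 gives a 1.3-fold lower number from compound 3 to compound 4 (0.12 log units; within the scatter), within the scatter, so the six-membered ring is not required at this level.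

The compounds shown do not separate the part played by the methylene link from that of the urea carbonyl. Also open, as far as these compounds go, is how a cyclohexyl group, a longer chain or a carboxylic acid in place of the isopropyl group would read in this assay.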